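A methyl on the aromatic nitrogen of compound 3

The source may hold more compounds than are shown below. What is called first, only, known or untested is meant among the compounds shown, and "the series" means these compounds.

Three compounds share one core and differ only in the group on an oxygen on an aromatic ring. In a functional assay on A549 cells (Homo sapiens) for antiproliferative activity, read by MTT assay, with a stated time of 48 h (a higher number here means a weaker inhibitor, a lower number a stronger inhibitor), compound 1 `COc1cc(-c2nnc3c(OC)cc(-c4ccc5[nH]ccc5c4)cn23)cc(OC)c1OC`, with methyl there, gives 167 nM. With oxetan-3-yl, compound 2 `COc1cc(-c2nnc3c(OC4COC4)cc(-c4ccc5[nH]ccc5c4)cn23)cc(OC)c1OC` gives 9810 nM, and with cyclobutyl, compound 3 `COc1cc(-c2nnc3c(OC4CCC4)cc(-c4ccc5[nH]ccc5c4)cn23)cc(OC)c1OC` gives 232 nM. Compound 3 therefore stands level with compound 1 and far from compound 2. The measured steps are a 1.4-fold higher number from compound 1 to compound 3 (0.14 log units; within the scatter), a 59-fold higher number from compound 1 to compound 2 (1.77 log units; beyond the scatter) and a 42-fold lower number from compound 2 to compound 3 (1.63 log units; beyond the scatter).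

Compound 4 `COc1cc(-c2nnc3c(OC4CCC4)cc(-c4ccc5c(ccn5C)c4)cn23)cc(OC)c1OC` keeps the cyclobutyl group and changes a different place: methyl in place of hydrogen on an aromatic nitrogen. This is methyl in place of hydrogen on an aromatic nitrogen, which turns 1H-indol-5-yl into 1-methyl-1H-indol-5-yl. All three measured steps changed the group on oxygen, and none touched this nitrogen. They show that a single change on this core can be small or large, but they do not say how this one will behave. With no direct evidence, the working expectation in this assay is no shift beyond the scatter, with only a slight lean towards a higher number. The expected step is a 1.3-fold higher number from compound 3 to compound 4 (0.11 log units; within the scatter). For compound 4 the estimated value is 300 nM, with an expected range from 80 nM to 1500 nM.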

Compound 4, half-maximal inhibitory concentration: 176 nM
Compound 4: middle estimate off by 1.7-fold (0.23 log units), on the high side; the range from low to high includes it.
By their numbers in this assay, from the lowest: compounds 1, 4 and 3 (each within the scatter of the next); then compound 2.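

In this assay the methyl on the aromatic nitrogen gives a 1.3-fold lower number from compound 3 to compound 4 (0.12 log units; within the scatter) and so the two compounds read as level. Going by these compounds alone, every earlier step changed the group on oxygen, so this is the first reading at this second place on the shared core, and it shows that, with cyclobutyl on the oxygen, the hydrogen on this nitrogen can be replaced by methyl with no shift that stands out from the scatter of the assay. Nothing measured here offers an explanation for this result, so it remains a plain observation about one pair of compounds.

On these data alone, whether this nitrogen accepts anything larger stays open, since an ethyl group, a longer chain, or a chain ending in an amine or a carboxylic acid might behave quite differently from methyl. Also open, as far as these compounds go, is whether methyl on this nitrogen would leave the number just as unmoved with another group on the oxygen, such as the oxetan-3-yl of compound 2 at 9810 nM in this assay where the number is already far higher.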